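The source may report more compounds than this note shows. Statements on the series, on what has been measured and on what is new or still open speak of the compounds shown alone.

Measured compounds:
compound 1, `COc1cc(Cl)cc(-c2nn(-c3cccc(NC(=O)c4ccc(Cl)c(Cl)c4)c3)cc2-c2ccncc2)c1`, gives 88.5%
compound 2, `O=C(Nc1cccc(-n2cc(-c3ccncc3)c(-c3cc(O)cc(Cl)c3)n2)c1)Nc1ccc(Cl)c(C(F)(F)F)c1`, gives 18.7%

Both were tested in a functional assay on DU-145 cells (Homo sapiens) for inhibition, read by sulforhodamine B assay, with a stated time of 48 h, tested at 10 uM; a higher number here means a weaker effect of the compound at the concentration tested, a lower number a stronger effect. Of the two numbers, compound 2 stands lowest, with 18.7%, and compound 1 stands far higher at 88.5%, a gap beyond the usual scatter. Compound 3, `O=C(Nc1cccc(-n2cc(-c3ccncc3)c(-c3cc(O)cc(Cl)c3)n2)c1)Nc1ccc(Cl)c(Cl)c1`, has not yet been measured. It differs from compound 2 in one place: chloro in place of trifluoromethyl on an aromatic carbon. For the measured compounds named here, no step between two measured compounds tracks this exchange, so there is no measured precedent for its size. The change is small in what leaves and what enters, and the rest of compound 2 is kept. The step from compound 2 to compound 3 is therefore expected to be small, a number 5.3 percentage points higher from compound 2 to compound 3 (within the scatter), and not beyond the scatter in either direction. Compound 3 is expected to give about 24%, within a range of 8% to 48%.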

Compound 3, a percentage reported as activity, at one concentration (the size of the read-out at that concentration, not a potency): -15.1%
The estimate for compound 3 lay 39.1 percentage points above the measured number; measured number outside the range, below it.
By their numbers in this assay, from the lowest: compound 3; then compound 2; then compound 1.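

In this assay, for the compounds shown here, the exchange of trifluoromethyl for chloro proves far from small: a number 33.8 percentage points lower from compound 2 to compound 3 (beyond the scatter), although only this one group changes and the rest of compound 2 is kept. Going by these compounds alone, it is the first sign that this place on the ring, ortho to a chloro group and meta to a large group, bears strongly on the read-out, with the 3,4-dichlorophenyl group giving a stronger effect than the 4-chloro-3-(trifluoromethyl)phenyl group at the concentration tested. Nothing on hand accounts for a step of this size.

As far as these compounds go, this rests on a single pair, so it remains open whether the same exchange would have a similar effect on another part of the series. The compounds shown also leave open what a bromo group, a nitrile or an amine would give at this place.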